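The compounds below may be only part of what the source reports. "The series", "measured", "known", "first", "only" and "open" are said of these compounds alone.

Three compounds that share one core have been run in a functional assay on the whole organism (strain Wistar albino) for inhibition, with Rattus norvegicus as the target, read by paw edema, with a stated time of 1 h, at a dose of 25 mg/kg by the oral route; on this read-out lower numbers stand for less inhibition and higher numbers for more inhibition at the one dose given (going by the name of the read-out). Compound 1 `CSc1nn(-c2ccccc2)c2nc(Nc3ccccc3)n(-c3ccccc3)c(=O)c12` gives 46.1%. Compound 2 `CSc1nn(-c2ccc([N+](=O)[O-])cc2)c2nc(Nc3ccccc3)n(-c3ccccc3)c(=O)c12` gives 42.1%, and compound 3 `CSc1nn(-c2ccc(S(N)(=O)=O)cc2)c2nc(Nc3ccccc3)n(-c3ccccc3)c(=O)c12` gives 68.9%. On these numbers compound 1 stands second highest of the three: the step of a number 4 percentage points lower from compound 1 to compound 2 (within the scatter) lies within the scatter, while the step of a number 22.8 percentage points higher from compound 1 to compound 3 (beyond the scatter) is beyond it, as is the step of a number 26.8 percentage points higher from compound 2 to compound 3 (beyond the scatter).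

Compound 4 `O=c1c2c(Nc3ccccc3)nn(-c3ccccc3)c2nc(Nc2ccccc2)n1-c1ccccc1` differs from compound 1 in a single place: anilino in place of methylsulfanyl on an aromatic carbon. Among the measured compounds shown here, none of the measured steps touches this part of the core; all three vary the group carried by a phenyl ring and leave the methylsulfanyl untouched. They therefore give no direct guide to the change in hand. What they do show is that a change on an outer group can leave the read-out essentially unchanged, as in the first of those steps, or raise it modestly, as the sulfamoyl does. With nothing pointing in either direction, the expectation for compound 4 is a step of about the scatter's size, namely a number 0.1 percentage points lower from compound 1 to compound 4 (within the scatter), which is an estimate rather than a measurement. Compound 4 is thus estimated at 46%, with a range from 30% to 62%.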

Compound 4, a percentage reported as inhibition, in the whole organism at one dose (the size of the read-out at that dose, not a potency): 48.1%
Estimate against measurement, compound 4: 2.1 percentage points below; measured number inside the range.
By their numbers in this assay, from the lowest: compounds 2, 1 and 4 (each within the scatter of the next); then compound 3.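

At the carbon of the five-membered ring that lies next to the ring nitrogen, anilino in place of methylsulfanyl gives a step of a number 2 percentage points higher from compound 1 to compound 4 (within the scatter) in this assay, so the two compounds cannot be told apart on this read-out. The swap is not a small one on paper: 2 heavy atoms with no ring leave, while 7 heavy atoms with a six-membered aromatic ring and a hydrogen-bond donor enter, and this single pair shows that such a swap at this carbon can be made without a step beyond the scatter. The earlier compounds varied only a group on a phenyl ring, so this is the first reading on the methylsulfanyl position itself, and no measurement shown here accounts for the result.

One pair cannot show whether any group would do as well at this carbon, and an amine, a carboxylic acid or a longer alkylsulfanyl chain there could give quite a different number. It also remains open whether the sulfamoyl group on the phenyl ring, which gave the one clear rise among these compounds, would give a similar step if the same core carried anilino rather than methylsulfanyl.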